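Bromoacetamide chalcone series: tail swap from decyl to 4-bromobenzyl

This account rests on a few compounds, and the source may have more. Where it says the series, first, only, none or still open, it means among the compounds named here.

Measured so far in a functional assay on MCF7 cells (Homo sapiens) for inhibition, read by MTT assay; a lower number here means a stronger inhibitor, a higher number a weaker inhibitor:
compound 1 `O=C(CN1CCN(c2ccccc2)CC1)Nc1ccc(C(=O)/C=C/c2cn(Cc3ccc(Br)cc3)nn2)cc1` gives 49200 nM;
compound 2 `CCCCCCCCCCn1cc(/C=C/C(=O)c2ccc(NC(=O)CBr)cc2)nn1` gives 9760 nM;
compound 3 `CCCCCCCCCCn1cc(/C=C/C(=O)c2ccc(N)cc2)nn1` gives 52600 nM.

Compound 2 stands lowest of the three numbers, with compound 1 and compound 3 both well above it. Going by the values given here, the only single-place step in hand is a 5.4-fold higher number from compound 2 to compound 3 (0.73 log units; beyond the scatter), which concerns the amide end, not the tail.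

Compound 4 `O=C(CBr)Nc1ccc(C(=O)/C=C/c2cn(Cc3ccc(Br)cc3)nn2)cc1` differs from compound 2 by 4-bromophenyl in place of nonyl on a saturated chain carbon bound to an aromatic nitrogen. Among the compounds with values here, no measured step bears on this change directly: compound 1 carries the same 4-bromobenzyl tail but a different amide, and its value sits near that of compound 3. Nothing in the data separates the two tails, so a step in this assay of at most modest size, toward a higher number, is expected.

Compound 4 is therefore estimated at 15000 nM, between 5000 nM and 45000 nM. The expected step is a 1.5-fold higher number from compound 2 to compound 4 (0.19 log units; within the scatter).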

Compound 4, half-maximal inhibitory concentration: 10100 nM
Compound 4: middle estimate off by 1.5-fold (0.17 log units), on the high side; the range from low to high includes it.
By their numbers in this assay, from the lowest: compounds 2 and 4 (each within the scatter of the next); then compounds 1 and 3 (each within the scatter of the next).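

In this assay, 4-bromophenyl in place of nonyl on a saturated chain carbon bound to an aromatic nitrogen gives a 1.0-fold higher number from compound 2 to compound 4 (0.01 log units; within the scatter), so with the bromoacetamide end in place, this position does not separate the decyl and 4-bromobenzyl tails. With the 4-bromobenzyl tail held, bromo in place of 4-phenylpiperazin-1-yl on a saturated chain carbon bound to a carbonyl carbon gives a 4.9-fold lower number from compound 1 to compound 4 (0.69 log units; beyond the scatter), so the amide end moves the number under this tail. No available evidence explains either step.

Still open, from the compounds shown here alone, is whether an unsubstituted benzyl or a shorter alkyl chain at the tail would also match the decyl and 4-bromobenzyl tails. Also open, going by these compounds, is how chloro in place of bromo on the acetamide would behave.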